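A few compounds are considered here, and "the series" means these few. Any claim that something is new, unique, unknown or untested is made for them only; others in the source may bear on it.

Compound 1 `NS(=O)(=O)c1nnc(NCc2nc3ccccc3[nH]2)s1` was tested in a functional assay on HCT-116 cells (Homo sapiens) for cytotoxicity, read by MTT assay (on this read-out lower numbers stand for stronger inhibition and higher numbers for weaker inhibition), where compound 1 gives 156000 nM. Among the three compounds measured, compound 1 stands second highest. Compound 2 `O=[N+]([O-])c1ccc2[nH]c(CNc3c([N+](=O)[O-])ccc4ncccc34)nc2c1` gives 256000 nM, a value within the scatter of compound 1. Compound 3 `COc1ccc2c(c1)CCC/C2=N\NCc1nc2cc([N+](=O)[O-])ccc2[nH]1` gives 45000 nM, which lies beyond the scatter from compound 1. Compound 4 `NS(=O)(=O)c1nnc(NCc2nc3cc([N+](=O)[O-])ccc3[nH]2)s1` has not yet been measured. It differs from compound 1 in one place: nitro in place of hydrogen on an aromatic carbon. For the measured compounds named here, no step between two measured compounds shows this change by itself, and compounds 2 and 3, which both carry a nitro group, span the whole range seen, so the change points in no clear direction. Compound 4 is therefore expected to show a step of a 1.3-fold lower number from compound 1 to compound 4 (0.11 log units; within the scatter), not beyond the scatter. The estimate for compound 4 is 120000 nM, with a range from 40000 nM to 350000 nM.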

Compound 4, half-maximal inhibitory concentration: 176000 nM
For compound 4 the middle estimate is 1.5-fold (0.17 log units) below the measured one, and the stated range covers the measured number.
By their numbers in this assay, from the lowest: compound 3; then compounds 1, 4 and 2 (each within the scatter of the next).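

Nitro in place of hydrogen on an aromatic carbon of the six-membered ring gives a 1.1-fold higher number from compound 1 to compound 4 (0.05 log units; within the scatter) in this assay, a step within the scatter. For the compounds shown here, this is the first reading of this change by itself, which compounds 2 and 3 could not give, as they differ from compound 1 in more than one place. Nothing measured here bears on why the number stays within the scatter. Still open, on these data alone, is whether an amine or a carboxylic acid in this same place would also leave the number within the scatter.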